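Swapping a Bicyclic Aryl Group for a Small Furan

A few compounds are considered here, and "the series" means these few. Any claim that something is new, unique, unknown or untested is made for them only; others in the source may bear on it.

Compound 1 `CC(C(=O)NCc1ccc(C(F)(F)F)nc1-c1ccc(N(C)C)cc1)c1ccc(NS(C)(=O)=O)c(F)c1`: 3.2 nM
Compound 2 `Cc1cc(-c2nc(C(F)(F)F)ccc2CNC(=O)C(C)c2ccc(NS(C)(=O)=O)c(F)c2)ccc1F`: 0.4 nM
Compound 3 `CC(C(=O)NCc1ccc(C(F)(F)F)nc1-c1ccc2c(c1)OCCO2)c1ccc(NS(C)(=O)=O)c(F)c1`: 5 nM

Three compounds share one core and differ only in the aromatic group attached to it. In an assay on CHO cells for antagonist activity at transient receptor potential cation channel subfamily V member 1 (Homo sapiens), read by FLIPR (a lower number here means a stronger inhibitor, a higher number a weaker inhibitor), compound 1 gives 3.2 nM, compound 2 gives 0.4 nM and compound 3 gives 5 nM. Compound 3 has the highest number of the three, but its distance from compound 1 is small (a 1.6-fold higher number from compound 1 to compound 3 (0.19 log units; within the scatter)), while its distance from compound 2 is large (a 13-fold higher number from compound 2 to compound 3 (1.10 log units; beyond the scatter)).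

Compound 4 `CC(C(=O)NCc1ccc(C(F)(F)F)nc1-c1ccoc1)c1ccc(NS(C)(=O)=O)c(F)c1` arises from compound 3 by furan-3-yl in place of 2,3-dihydro-1,4-benzodioxin-6-yl on an aromatic carbon. All three measured steps change the group in this same place. The steps of an 8.0-fold lower number from compound 1 to compound 2 (0.90 log units; beyond the scatter) and a 13-fold higher number from compound 2 to compound 3 (1.10 log units; beyond the scatter) show that the choice of group here can move the number strongly, whereas a 1.6-fold higher number from compound 1 to compound 3 (0.19 log units; within the scatter) shows that it can also leave the number essentially unchanged. Among the measured compounds shown here, none of the measured groups resembles a furan, so the direction of this step is uncertain; a modest move in either direction, or none beyond the scatter, seems most plausible, with somewhat more room on the side of a higher number. Compound 4 is therefore expected to give about 10 nM, within 2.5 nM to 40 nM, which corresponds to an estimated step of a 2.0-fold higher number from compound 3 to compound 4 (0.30 log units; within the scatter).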

Compound 4, inhibition constant: 1.4 nM
Beside the measured number, compound 4's estimate is 7.1-fold (0.85 log units) above it; the whole stated range lies above it.
By their numbers in this assay, from the lowest: compound 2; then compound 4; then compounds 1 and 3 (each within the scatter of the next).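

In this assay, a much smaller group can hold this place without any loss: furan-3-yl, with fewer heavy atoms than the 2,3-dihydro-1,4-benzodioxin-6-yl group, gives a better result (a 3.6-fold lower number from compound 3 to compound 4 (0.55 log units; beyond the scatter)). The same single five-membered aromatic ring also improves on the 4-(dimethylamino)phenyl group (a 2.3-fold lower number from compound 1 to compound 4 (0.36 log units; beyond the scatter)), so among these compounds a six-membered aromatic ring of carbon only is not needed here for a number in the low nanomolar range. The 4-fluoro-3-methylphenyl group still keeps its lead over furan-3-yl (a 3.5-fold higher number from compound 2 to compound 4 (0.54 log units; beyond the scatter)), so the number does not simply follow the size of the group: the smallest group here gives neither the lowest nor the highest number, and compound 2 remains the strongest inhibitor of the four.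

Still open, as far as these compounds go, is how a thiophen-3-yl, pyridin-3-yl or unsubstituted phenyl group at this place would compare with furan-3-yl and with the 4-fluoro-3-methylphenyl group. No measurement in hand accounts for this ranking of the four groups.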